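Replacing methylsulfanyl with hydrogen in compound 2

The source may report more compounds than this note shows. Statements on the series, on what has been measured and on what is new or still open speak of the compounds shown alone.

In an ADME assay on HEL cells (Homo sapiens) for cytotoxicity (a higher number here means that more compound is tolerated, a lower number that less compound is tolerated), compound 1 `O=C(COc1cccc2ccccc12)N/N=C/c1ccc(Br)cc1` gives 100 ug/mL. Compound 2 `CSc1ccc(/C=N/NC(=O)COc2cccc3ccccc23)cc1` reads > 100 ug/mL, which is a limit of the assay and not a number. Compound 3 `O=C(COc1cccc2ccccc12)N/N=C/c1ccccc1` carries hydrogen in place of methylsulfanyl on an aromatic carbon of compound 2, para to a large group: hydrogen in place of methylsulfanyl on an aromatic carbon. Among the compounds with values here, the one measured step at this place is a number no lower from compound 1 to compound 2 (the limit leaves the size open), and its size stays open. No clear direction can be read from it, so a change beyond the scatter is not expected. The expected step is a number no higher from compound 2 to compound 3 (the limit leaves the size open). The estimate for compound 3 is 100 ug/mL, with an expected range of 50 ug/mL to 200 ug/mL.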

Compound 3, half-maximal cytotoxic concentration in the HEL assay: 64.5 ug/mL
The estimate for compound 3 lay 1.6-fold (0.19 log units) above the measured number; the measured number falls inside the stated range.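

In the HEL assay, hydrogen in place of bromo gives a 1.6-fold lower number from compound 1 to compound 3 (0.19 log units; within the scatter). In the HEL assay, hydrogen in place of methylsulfanyl gives an at least 1.5-fold lower number from compound 2 to compound 3 (0.19 log units; that floor lies within the scatter). Going by these compounds, compound 2 stands at a limit of the assay, so the size of its step stays open: the limit of > 100 ug/mL in the HEL assay, at which 1 of the 3 values shown sits. In a physicochemical assay for lipophilicity, measured as octanol-water partition (on this read-out higher numbers stand for higher lipophilicity and lower numbers for lower lipophilicity), compound 2 gives 4.11 and compound 3 gives 4.02, and hydrogen in place of methylsulfanyl gives a number 0.09 log units lower from compound 2 to compound 3 (within the scatter).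

Still open, on these data alone, is the number for compound 2 in the HEL assay. Also open, as far as these compounds go, is whether an amine or a carboxylic acid on this aromatic carbon would give a step beyond the scatter.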